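A few compounds are considered here, and "the series" means these few. Any claim that something is new, unique, unknown or untested is made for them only; others in the source may bear on it.

In a functional assay on HL-60 cells (Homo sapiens) for inhibition, read by MTT assay, with a stated time of 72 h (a higher number here means a weaker inhibitor, a lower number a stronger inhibitor), compound 1 `Cc1nc(-c2ccccc2)c(C(=O)N2CCN(c3cccc(Cl)c3)CC2)o1` gives 39.2 nM. Compound 2 `Cc1nc(-c2cccc(F)c2)c(C(=O)N2CCN(c3cccc(Cl)c3)CC2)o1`, at 33.7 nM, lies within the scatter of it, while compound 3 `CC(=O)Nc1cccc(-c2nc(C)oc2C(=O)N2CCN(c3cccc(Cl)c3)CC2)c1`, at 208 nM, has the highest number of the three. Compound 4 `Cc1ccc(C)c(N2CCN(C(=O)c3oc(C)nc3-c3ccccc3)CC2)c1` carries 2,5-dimethylphenyl in place of 3-chlorophenyl on an amine nitrogen in a ring. For the measured compounds named here, no measured step changes that place, so the others bear on it only indirectly, as a guide to size: fluoro in place of hydrogen gave a 1.2-fold lower number from compound 1 to compound 2 (0.07 log units; within the scatter), and acetamido in place of hydrogen gave a 5.3-fold higher number from compound 1 to compound 3 (0.72 log units; beyond the scatter). A small step toward a weaker inhibitor is therefore expected, an estimated 1.8-fold higher number from compound 1 to compound 4 (0.25 log units; within the scatter). Compound 4 is estimated at 70 nM, with an expected range of 20 nM to 240 nM.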

Compound 4, half-maximal inhibitory concentration: 31.3 nM
The estimate for compound 4 lay 2.2-fold (0.35 log units) above the measured number; the range from low to high includes it.
By their numbers in this assay, from the lowest: compounds 4, 2 and 1 (each within the scatter of the next); then compound 3.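

In this assay, 2,5-dimethylphenyl in place of 3-chlorophenyl on the amine nitrogen in the ring gives a 1.3-fold lower number from compound 1 to compound 4 (0.10 log units; within the scatter). In this pair, then, the chlorine is not needed to keep the number where it stands, and an aromatic ring with two methyl groups serves equally well at this position. No measurement shown explains why these two groups read alike. Going by these compounds, it remains open how this position would respond to something other than a substituted phenyl, such as a benzyl group or a longer chain. On these data alone, whether an amine on this phenyl ring would shift the number also remains unknown.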